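Working Notes: Fluorophenyl Exchange and Seizure Protection

A few compounds are considered here, and "the series" means these few. Any claim that something is new, unique, unknown or untested is made for them only; others in the source may bear on it.

The series is followed in a functional assay on the whole organism (strain Swiss) with Mus musculus as the target, in the maximal electroshock model, with a stated time of 0.5 h, at a dose of 100 mg/kg by the intraperitoneal route; a lower number here means a weaker effect, a higher number a stronger effect of the compound at the dose given. Compound 1 `CCC(C(=O)N1CCN(c2cccc(F)c2)CC1)N1C(=O)CCC1=O` is inactive in this assay, giving 0%. Compound 2 `CC(C(=O)N1CCN(c2ccc(F)cc2)CC1)N1C(=O)CCC1=O` carries a shorter chain next to the carbonyl and a 4-fluorophenyl on the ring amine nitrogen; in this assay compound 2 gives 0%, level with compound 1 at the digits printed and within the scatter of it. Compound 3 `CC(C(=O)N1CCN(c2cccc(F)c2)CC1)N1C(=O)CCC1=O` is the unmeasured member. The change from compound 2 is 3-fluorophenyl in place of 4-fluorophenyl on an amine nitrogen in a ring; the two have the same atoms, joined differently. Within the data shown here, no step between measured compounds exists, and both numbers recorded sit at zero, so no shift beyond the scatter is expected: no change at the digits printed from compound 2 to compound 3 (within the scatter). Compound 3 is expected to give 0% in this assay, with a range from 0% to 10%.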

Compound 3, a percentage reported as activity, at one dose (the size of the read-out at that dose, not a potency): 0%
For compound 3 middle estimate and measured number coincide at the digits printed; low and high end bracket the measured number.
By their numbers in this assay, from the lowest: compounds 1, 2 and 3 (each within the scatter of the next).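

In this assay, the fluorine position and the chain can each now be read as a single change: 3-fluorophenyl in place of 4-fluorophenyl on an amine nitrogen in a ring gives no change at the digits printed from compound 2 to compound 3 (within the scatter), and hydrogen in place of methyl on a saturated chain carbon gives no change at the digits printed from compound 1 to compound 3 (within the scatter). Neither change brings out any protection at the dose given, and both comparisons start and end with no measurable effect. No measured evidence bears on these results.

On these data alone, whether a chlorine atom or a methoxy group on the phenyl ring, or a longer chain on the saturated chain carbon, would produce a measurable effect remains open. With all three compounds level, the series cannot yet show whether either place influences activity.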